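Chalcone series: cytotoxicity in HaCaT cells, nitro analogue

This account rests on a few compounds, and the source may have more. Where it says the series, first, only, none or still open, it means among the compounds named here.

The shared core carries a trimethoxy-substituted ring, with the enone linking to a second aromatic ring. Compound 1 `COc1cc(O)c(C(=O)/C=C/c2ccc(F)cc2)c(OC)c1` differs in bearing a hydroxy group and a fluoro substituent; in a functional assay on HaCaT cells (Homo sapiens) for cytotoxicity, with a stated time of 48 h (on this read-out higher numbers stand for weaker inhibition and lower numbers for stronger inhibition), compound 1 shows only a limit of the assay, > 20000 nM. Compound 2 `COc1cc(OC)c(C(=O)/C=C/c2ccccc2SC)c(OC)c1` carries a methylsulfanyl group and gives 7700 nM. Compound 3 `COc1cc(OC)c(C(=O)/C=C/c2ccccc2)c(OC)c1`, the unsubstituted parent, gives 7200 nM, the lowest of the two numbers shown, though the step of a 1.1-fold lower number from compound 2 to compound 3 (0.03 log units; within the scatter) stays within the scatter.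

Compound 4 `COc1cc(OC)c(C(=O)/C=C/c2ccc([N+](=O)[O-])cc2)c(OC)c1` is the next analogue: nitro in place of hydrogen on an aromatic carbon. Within the data shown here, no measured step introduces a nitro group, so the only step on this ring, from compound 2 to compound 3, is the sole guide; it involved removal of a substituent from the same ring and stayed within the scatter. On that basis no step beyond the scatter is expected in this assay, in either direction. For compound 4 the expected step is a 1.0-fold lower number from compound 3 to compound 4 (0.01 log units; within the scatter). The estimate for compound 4 is therefore 7000 nM, with a range from 3000 nM to 20000 nM; the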

Compound 4, half-maximal inhibitory concentration: 2800 nM
Beside the measured number, compound 4's estimate is 2.5-fold (0.40 log units) above it; the measured number lies below the stated range.
By their numbers in this assay, from the lowest: compound 4; then compounds 3 and 2 (each within the scatter of the next). At a limit, above all of these: compound 1.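

Nitro in place of hydrogen, para to a large group, gives the first step in this series that clears the scatter: in this assay, a 2.6-fold lower number from compound 3 to compound 4 (0.41 log units; beyond the scatter). The earlier step on this ring, a 1.1-fold lower number from compound 2 to compound 3 (0.03 log units; within the scatter), stayed within the scatter and could not show whether a substituent on this ring changes the read-out at all; the new step shows that one such change does, although the size of the step remains modest. The compounds shown hold no measurement that explains this step, so the nitro group's contribution is recorded here only as an observed change in the read-out.

Among these compounds, compound 1 gives only a limit of the assay, > 20000 nM, and it differs from the other compounds in more than one place, so no step involving it can be read. Still open, as far as these compounds go, is whether the lower number belongs to nitro specifically or would also appear with another group in the same place, such as an amine, a carboxylic acid or a nitrile, and whether nitro would give the same step elsewhere on this ring.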